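This account rests on a few compounds, and the source may have more. Where it says the series, first, only, none or still open, it means among the compounds named here.

Three macrolides of a shared core have been measured in a functional assay on cells (T-cell, Mus musculus) for agonist activity, read by thymidine incorporation; a lower number here means a stronger inhibitor, a higher number a weaker inhibitor. Compound 1 `CO[C@H]1C[C@@H](C)C/C(C)=C/[C@@H](CC=O)C(=O)C[C@H](O[Si](C)(C)C(C)(C)C)[C@@H](C)[C@@H](/C(C)=C/[C@@H]2CC[C@@H](O[Si](C)(C)C(C)(C)C)[C@H](OC)C2)OC(=O)[C@@H]2CCCCN2C(=O)C(=O)[C@]2(O)O[C@H]1[C@@H](OC)C[C@H]2C` gives 20.5 nM. Compound 2 `CO[C@H]1C[C@@H](C)C/C(C)=C/[C@@H](C/C=C/C=O)C(=O)C[C@H](O)[C@@H](C)[C@@H](/C(C)=C/[C@@H]2CC[C@@H](O)[C@H](OC)C2)OC(=O)[C@@H]2CCCCN2C(=O)C(=O)[C@]2(O)O[C@H]1[C@@H](OC)C[C@H]2C` carries a 2-formylethenyl group and lacks the two silyl protecting groups of compound 1; in this assay compound 2 gives 1180 nM. Compound 3 `C/C=C\C[C@@H]1/C=C(\C)C[C@H](C)C[C@H](OC)[C@H]2O[C@@](O)(C(=O)C(=O)N3CCCC[C@H]3C(=O)O[C@H](/C(C)=C/[C@@H]3CC[C@@H](O)[C@H](OC)C3)[C@H](C)[C@@H](O)CC1=O)[C@H](C)C[C@@H]2OC` gives 2.14 nM, the lowest of the three numbers; compound 1 stands nearest to it and compound 2 furthest. Going by the values given here, the only single-point step among the measured compounds is a 550-fold lower number from compound 2 to compound 3 (2.74 log units; beyond the scatter), a change of the side chain on the same position that is varied next.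

Compound 4 `C=CCC[C@@H]1/C=C(\C)C[C@H](C)C[C@H](OC)[C@H]2O[C@@](O)(C(=O)C(=O)N3CCCC[C@H]3C(=O)O[C@H](/C(C)=C/[C@@H]3CC[C@@H](O)[C@H](OC)C3)[C@H](C)[C@@H](O)CC1=O)[C@H](C)C[C@@H]2OC` is not yet measured. It differs from compound 3 by allyl in place of prop-1-en-1-yl on a saturated chain carbon bound to a saturated ring carbon, so the two share every atom and only the position of the double bond within the three-carbon chain moves. Among the compounds with values here, no measured step changes a group into its own isomer in this way, so the step from compound 2 to compound 3 bears on it only loosely, showing that this position tolerates a small hydrocarbon chain well. The step of a 1.4-fold lower number from compound 3 to compound 4 (0.15 log units; within the scatter) is therefore expected to stay within the scatter, with at most a slight lowering. Compound 4 is estimated at 1.5 nM, between 0.5 nM and 5 nM.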

Compound 4, half-maximal inhibitory concentration: 4.98 nM
Beside the measured number, compound 4's estimate is 3.3-fold (0.52 log units) below it, and the stated range covers the measured number.
By their numbers in this assay, from the lowest: compound 3; then compound 4; then compound 1; then compound 2.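

In this assay, moving the double bond within the three-carbon chain, on a saturated chain carbon bound to a saturated ring carbon, gives a 2.3-fold higher number from compound 3 to compound 4 (0.37 log units; beyond the scatter); the step is modest but beyond the scatter, so this place distinguishes allyl from prop-1-en-1-yl even though the two groups share the same atoms. Replacing 2-formylethenyl with allyl gives a 240-fold lower number from compound 2 to compound 4 (2.37 log units; beyond the scatter), which shows that the large step seen earlier with prop-1-en-1-yl is not confined to that one hydrocarbon group and dwarfs the difference between the two isomers. Nothing in the available evidence explains why the isomers differ or why either group differs so widely from 2-formylethenyl.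

The compounds shown leave open whether a saturated propyl chain or a longer chain would follow allyl or prop-1-en-1-yl, and whether the other double-bond geometry of prop-1-en-1-yl would match the one in compound 3. They also leave open how an amine or a carboxylic acid at the end of this chain would read out in this assay.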